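What replacing penta-1,3-dien-1-yl with but-1-en-1-yl may do

This account rests on a few compounds, and the source may have more. Where it says the series, first, only, none or still open, it means among the compounds named here.

Values in a functional assay on MGC-803 cells (Homo sapiens) for inhibition, read by MTT assay, with a stated time of 48 h; on this read-out lower numbers stand for stronger inhibition and higher numbers for weaker inhibition:
- compound 1 `COc1ccc(CN(C(=O)C(C)Br)c2cc(OC)c(OC)c(OC)c2)cc1O`: 120 nM
- compound 2 `C#CC(=O)N(Cc1ccc(OC)c(O)c1)c1cc(OC)c(OC)c(OC)c1`: 170 nM
- compound 3 `C/C=C/C=C/C(=O)N(Cc1ccc(OC)c(O)c1)c1cc(OC)c(OC)c(OC)c1`: 140 nM

Compound 3 cannot be told apart from the other two: the data show a 1.2-fold higher number from compound 1 to compound 3 (0.07 log units; within the scatter), and a 1.2-fold lower number from compound 2 to compound 3 (0.08 log units; within the scatter). The next structure is compound 4 `CC/C=C/C(=O)N(Cc1ccc(OC)c(O)c1)c1cc(OC)c(OC)c(OC)c1`, and its difference from compound 3 is this: ethyl in place of prop-1-en-1-yl on a double-bonded chain carbon bound to a double-bonded chain carbon. This places ethyl in place of prop-1-en-1-yl on a double-bonded chain carbon bound to a double-bonded chain carbon, so penta-1,3-dien-1-yl becomes but-1-en-1-yl. Within the data shown here, no measured step makes exactly this change. The closest evidence comes from swapping the whole group on the carbonyl carbon: besides the two steps above, there is a 1.4-fold higher number from compound 1 to compound 2 (0.15 log units; within the scatter). All three stayed within the scatter, so in this assay no step beyond the scatter is expected, and no direction can be favoured. The estimated step is a 1.2-fold higher number from compound 3 to compound 4 (0.08 log units; within the scatter). For compound 4 the expected value is 170 nM, with an estimated range from 70 nM to 450 nM.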

Compound 4, half-maximal inhibitory concentration: 58 nM
Estimate against measurement, compound 4: 2.9-fold (0.47 log units) above; the measured number lies below the stated range.
By their numbers in this assay, from the lowest: compound 4; then compounds 1, 3 and 2 (each within the scatter of the next).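

In this assay, the earlier swaps of the whole group on the carbonyl carbon all stayed within the scatter, which made this position look indifferent to the group it carries. Trimming the end of the chain, with ethyl in place of prop-1-en-1-yl, gives the first step here that lies beyond the scatter (a 2.4-fold lower number from compound 3 to compound 4 (0.38 log units; beyond the scatter)), so the position does respond to a change this small, if only modestly. Compound 4 also stands apart from the two other compounds (a 2.9-fold lower number from compound 2 to compound 4 (0.47 log units; beyond the scatter); a 2.1-fold lower number from compound 1 to compound 4 (0.32 log units; beyond the scatter)), and nothing shown here explains the difference.

The compounds shown leave open whether the double bond of but-1-en-1-yl is needed, as a saturated butyl chain would test. They also leave open whether a longer chain, or an amine at the end of the chain, would lower the number further.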